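Compound 2 to compound 4: reading from a limit

The source may report more compounds than this note shows. Statements on the series, on what has been measured and on what is new or still open speak of the compounds shown alone.

Compound 1 `O=C1OC(Cc2nc(-c3ccc(-c4ccccc4)cc3)no2)c2ccccc21` has the limit > 40000 nM
Compound 2 `CCCCCCOc1ccc(C(O)C2OC(=O)c3c(OC)cc(OC)cc32)cc1` has the limit > 40000 nM
Compound 3 `CCOCCOc1ccc(C(O)C2OC(=O)c3c(OC)cc(OC)cc32)cc1` has the limit > 40000 nM

These readings come from an ADME assay on RAW264.7 cells (Mus musculus) for cytotoxicity, read by MTT assay, with a stated time of 24 h, in the presence of a further agent that is not named here (a higher number here means a weaker inhibitor, a lower number a stronger inhibitor), and each is a limit, not a number. Compound 2 stands only at the limit > 40000 nM and has no number to start from. The change to compound 4 `C=CCCOc1ccc(C(O)C2OC(=O)c3c(OC)cc(OC)cc32)cc1` is vinyl in place of butyl on a saturated chain carbon, two bonds along the chain from an oxygen on an aromatic ring and, cut further out, reads hexyloxy to (but-3-en-1-yl)oxy. Among the compounds with values here, the one measured step at this place is a step that the two limits leave unreadable from compound 2 to compound 3 and it gives no size to carry over. Within the data shown here, all that remains is the limit of > 40000 nM in this assay, at which 3 of the 3 values shown sit, so that another limit in this assay is expected, with no step expected beyond the scatter in either direction. The expected step is a step that the limit leaves unreadable from compound 2 to compound 4 as an estimate only. For compound 4 the estimated value is 50000 nM with an expected range from 25000 nM to 100000 nM in this reading.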

Compound 4, half-maximal inhibitory concentration: > 40000 nM
Compound 4: only a limit was reported (the forecaster's own chance of this, stated with the estimate: 85%); the middle value does not contradict the limit.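

In this assay, within the data shown here, compound 4 gives > 40000 nM as a limit, so no step to it from compound 2 or compound 3 can be read: the limit of > 40000 nM in this assay, at which 4 of the 4 values shown sit. The compounds shown leave open whether any change on this chain moves the reading in this assay at all.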